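This account rests on a few compounds, and the source may have more. Where it says the series, first, only, none or still open, it means among the compounds named here.

- Compound 1 `O=C(NCc1ccc(S(=O)(=O)C2CCCCC2)cc1)N1Cc2ccncc2C1`: 16 mL/min/kg
- Compound 2 `CN1CCC(S(=O)(=O)c2ccc(CNC(=O)N3Cc4ccncc4C3)cc2)CC1`: 11 mL/min/kg

In an ADME assay on microsomes from liver (Homo sapiens) for pharmacokinetics, read by LC-MS, with a stated time of 60 min, tested at 1 uM (on this read-out higher numbers stand for fast clearance and lower numbers for slow clearance), compound 2 gives 11 mL/min/kg, and compound 1 gives 16 mL/min/kg. These two numbers lie within the usual scatter of each other, so neither compound can be ranked ahead of the other.

The next compound to be tested is compound 3 `O=C(NCc1ccc(S(=O)(=O)N2CC3(CCOCC3)C2)cc1)N1Cc2ccncc2C1`. It keeps the rest of compound 2 and changes only the group on the sulfonyl sulfur: a group of 9 heavy atoms (7 carbon, 1 nitrogen, 1 oxygen; one four-membered non-aromatic ring with 1 hetero atom, one six-membered non-aromatic ring with 1 hetero atom) in place of a group of 7 heavy atoms (6 carbon, 1 nitrogen; one six-membered non-aromatic ring with 1 hetero atom), on a sulfonyl sulfur. Going by the values given here, the incoming group carries a four-membered non-aromatic ring, and no measured compound here has such a ring, so the data offer no direct guide to it.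

Among the compounds with values here, only one measured step changes a group at this same place: a 1.5-fold lower number from compound 1 to compound 2 (0.16 log units; within the scatter). That swap of cyclohexyl for 1-methylpiperidin-4-yl stayed within the scatter, which is thin but real evidence that this assay may respond little to changes here. No shift beyond the scatter is therefore expected, in either direction. The expected change is a 1.1-fold higher number from compound 2 to compound 3 (0.04 log units; within the scatter). The estimated clearance of compound 3 is 12 mL/min/kg, with an expected range from 6 mL/min/kg to 24 mL/min/kg.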

Compound 3, clearance: 13 mL/min/kg
For compound 3 the middle estimate is 1.1-fold (0.03 log units) below the measured one; low and high end bracket the measured number.
By their numbers in this assay, from the lowest: compounds 2, 3 and 1 (each within the scatter of the next).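

A group holding a four-membered non-aromatic ring together with a six-membered one, a ring type absent from compound 1 and compound 2, can sit on the sulfonyl sulfur with only a 1.2-fold higher number from compound 2 to compound 3 (0.07 log units; within the scatter) in this assay. Set against the cyclohexyl group with its ring of carbon only, the same group gives a 1.2-fold lower number from compound 1 to compound 3 (0.09 log units; within the scatter), so all three groups tried at this place lie within the scatter of one another, and this read-out does not separate them even though the incoming group is the largest of the three by heavy atoms. That makes the earlier hint of a weak response here somewhat firmer, but no measurement is at hand that could explain it.

On these data alone, whether clearance stays as flat with a very different group on the sulfonyl sulfur, such as a carboxylic acid, a primary amine or a longer open chain, remains open. All three compounds also share the same core, so they leave open how much clearance would respond to a change anywhere else in the molecule.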